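The source may report more compounds than this note shows. Statements on the series, on what has been measured and on what is new or still open speak of the compounds shown alone.

Compound 1 `O=C(CN1CCN(c2ccccc2)CC1)Nc1nc2ccccc2[nH]1`, compound 2 `O=C(CN1CCN(c2ccc([N+](=O)[O-])cc2)CC1)Nc1nc2ccccc2[nH]1`.

In a functional assay, read by spectrophotometry, with a stated time of 30 min, tested at 150 ug/mL (a lower number here means a weaker effect, a higher number a stronger effect of the compound at the concentration tested), compound 1 gives 40.6%, and compound 2 gives 64.9%. Compound 1 thus stands lowest of the two numbers, with compound 2 the nearest and a number 24.3 percentage points higher from compound 1 to compound 2 (beyond the scatter).

Compound 3 `COc1ccccc1N1CCN(CC(=O)Nc2nc3ccccc3[nH]2)CC1` differs from compound 1 in one place: methoxy in place of hydrogen on an aromatic carbon. Within the data shown here, the only measured step, nitro in place of hydrogen, bears on it loosely, since a methoxy group is not a nitro group; it raised this assay moderately. For compound 3 a smaller rise is expected, a number 7.4 percentage points higher from compound 1 to compound 3 (within the scatter), likely within the scatter. Compound 3 is estimated at 48%, between 34% and 62%.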

Compound 3, a percentage reported as activity, at one concentration (the size of the read-out at that concentration, not a potency): 55.2%
Compound 3: the middle estimate sits 7.2 percentage points below what was measured; measured number inside the range.
By their numbers in this assay, from the lowest: compound 1; then compounds 3 and 2 (each within the scatter of the next).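

In this assay, the rise over the plain phenyl of compound 1 is not confined to nitro: methoxy on an aromatic carbon, ortho to a large group, also gives a number 14.6 percentage points higher from compound 1 to compound 3 (beyond the scatter). The change from 4-nitrophenyl to 2-methoxyphenyl gives a number 9.7 percentage points lower from compound 2 to compound 3 (within the scatter), so these two groups are not told apart here, although they differ in both identity and place. Nothing available explains either step.

Whether methoxy would read the same elsewhere on the ring stays open, as 4-methoxyphenyl is not among the compounds shown. Going by these compounds, how a hydroxyl group or a chlorine atom would read at this position is also open.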